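This account rests on a few compounds, and the source may have more. Where it says the series, first, only, none or still open, it means among the compounds named here.

Measured compounds so far:
compound 1, `CCOC(=O)C1(CCCCCc2ccc(Cl)cc2)CO1`; in a functional assay on the whole organism (blood) with Rattus norvegicus as the target (on this read-out lower numbers stand for an effect already at smaller amounts and higher numbers for an effect only at larger amounts of compound), compound 1 gives 20 umol/kg.
compound 2, `CCOC(=O)C1(CCCc2cccc(C(F)(F)F)c2)CO1`; in this assay compound 2 gives 170 umol/kg.
compound 3, `O=C(O)C1(CCCc2cccc(C(F)(F)F)c2)CO1`; in this assay compound 3 gives 80 umol/kg.

Compound 2 and compound 3 share one core and differ in a single place: hydrogen in place of ethyl on an oxygen next to a carbonyl group. That change gives a 2.1-fold lower number from compound 2 to compound 3 (0.33 log units; beyond the scatter). Compound 1 carries a different core; how the core of compound 1 differs from that of compound 2 is not broken down here. Compound 1 shows the lowest number of the three measured compounds, and its gaps to compound 3 and to compound 2 both lie beyond the scatter.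

Compound 4, `O=C(O)C1(CCCCCc2ccc(Cl)cc2)CO1`, is not yet measured. For the measured compounds named here, it differs from compound 1 by hydrogen in place of ethyl on an oxygen next to a carbonyl group, the same change as the one between compound 2 and compound 3, made at the same place. For the step in this assay the expectation is a 2.0-fold lower number from compound 1 to compound 4 (0.30 log units; within the scatter), resting on the measured step of a 2.1-fold lower number from compound 2 to compound 3 (0.33 log units; beyond the scatter) transferred to the core of compound 1. Compound 4 is accordingly expected to give about 10 umol/kg, with the likely range between 4 umol/kg and 30 umol/kg.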

Compound 4, dose for half-maximal effect: 30 umol/kg
Compound 4: the middle estimate sits 3.0-fold (0.48 log units) below what was measured, and the stated range covers the measured number.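

In this assay, the change from ethoxycarbonyl to carboxy on the core of compound 1 gives a 1.5-fold higher number from compound 1 to compound 4 (0.18 log units; within the scatter). Carrying the change from one core to the other in this series therefore does not preserve the size of the step, and the two measured steps differ: the same change on two cores in this assay, a 2.1-fold lower number (0.33 log units; beyond the scatter) from compound 2 to compound 3 and a 1.5-fold higher number (0.18 log units; within the scatter) from compound 1 to compound 4, 3.2-fold (0.50 log units) apart, beyond the scatter of two such steps. For the compounds shown here, this rests on only two matched pairs, so it shows that the step cannot be assumed to transfer between these two cores, but it does not show which difference between the cores accounts for the gap, nor does it give a rule for any other core.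

The compounds shown leave open how the step behaves when the chain and the ring substituent are varied separately, for example with the chlorine of compound 1 on the shorter chain of compound 2 or the trifluoromethyl group of compound 2 on the longer chain of compound 1. They also leave open whether a methyl ester or an amide in place of the ethyl ester or the carboxylic acid would follow either step.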